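The source may hold more compounds than are shown below. What is called first, only, known or untested is meant among the compounds shown, and "the series" means these compounds.

Of the compounds shown here, three built on one shared core have been tested in a functional assay on ileum (strain Hartley) for agonist activity at 5-hydroxytryptamine receptor 3A (Cavia porcellus); on this read-out lower numbers stand for lower potency and higher numbers for higher potency (the scale is a negative logarithm). Compound 1, `CCOC(=O)c1ccc2oc(N3CCN(C)CC3)nc2c1`, gives < 4 there, which is a limit of the assay and not a number. Compound 2, `CN1CCN(c2nc3cc(C(F)(F)F)ccc3o2)CC1`, gives < 4 in this assay, again a limit rather than a number. Going by the values given here, compound 3, `COc1ccc2oc(N3CCN(C)CC3)nc2c1`, is the only one with a number: in this assay compound 3 gives 4.78, so it stands as the sole readable value among the three. The step of a number at least 0.78 log units higher from compound 1 to compound 3 (beyond the scatter) and the step of a number at least 0.78 log units higher from compound 2 to compound 3 (beyond the scatter) both point upward, each placing methoxy on the aromatic carbon in place of another group, and each can only be read as a minimum because two of the three values sit at the limit of < 4 in this assay, at which 2 of the 3 values shown sit. Compound 4, `CN1CCN(c2nc3cc(F)ccc3o2)CC1`, is not yet measured. It differs from compound 3 by fluoro in place of methoxy on an aromatic carbon. Among the compounds with values here, no measured step exchanges methoxy for fluoro, so the two upward steps show only that methoxy fares better in this assay than ethoxycarbonyl or trifluoromethyl; they say nothing direct about fluoro. The step of a number 0.38 log units lower from compound 3 to compound 4 (beyond the scatter) is therefore expected to be a small fall, with some chance that only a limit is reported. Compound 4 is estimated at 4.4, expected to lie between 3.8 and 5.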

Compound 4, negative logarithm of the half-maximal effective concentration: 5.57
Compound 4: middle estimate off by 1.17 log units, on the low side; measured number outside the range, above it.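

Fluoro in place of methoxy gives a number 0.79 log units higher from compound 3 to compound 4 (beyond the scatter), so in this assay methoxy no longer ranks first among the groups at this aromatic carbon, and the order now has fluoro on top. Fluoro in place of trifluoromethyl gives a number at least 1.57 log units higher from compound 2 to compound 4 (beyond the scatter), and fluoro in place of ethoxycarbonyl gives a number at least 1.57 log units higher from compound 1 to compound 4 (beyond the scatter), which places compound 4 clearly above both. These two larger steps are minimum sizes and not exact ones, because compound 1 and compound 2 each carry a limit of the assay and not a number: the limit of < 4 in this assay, at which 2 of the 4 values shown sit.

The compounds shown leave open how a chlorine atom, a plain hydrogen or an amine at this aromatic carbon would compare with fluoro, so it remains unknown whether fluoro is an isolated high point or one member of a wider group that does well here. They also leave open whether fluoro would still stay ahead of methoxy if another part of the shared core were changed, since all four compounds differ in this one place only.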